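Changing the group on sulfur in compound 2

The source may report more compounds than this note shows. Statements on the series, on what has been measured and on what is new or still open speak of the compounds shown alone.

In a functional assay on HCT-116 cells (Homo sapiens) for inhibition, read by CCK-8 assay, with a stated time of 72 h, tested at 8 uM (on this read-out higher numbers stand for more inhibition of growth at the one concentration tested and lower numbers for less inhibition of growth), compound 2 (`CCc1ccc(SCc2ccc(/C=C/C(=O)Nc3ccccc3N)cc2)cc1`) gives 2.68% and compound 1 (`Cc1cc(C)cc(SCc2ccc(/C=C/C(=O)Nc3ccccc3N)cc2)c1`) gives 4.2% on the same read-out. These two numbers cannot be told apart, and both show little effect on growth at the single concentration tested.

Compound 3 (`Nc1ccccc1NC(=O)/C=C/c1ccc(CSc2ccc(C(F)(F)F)cn2)cc1`) keeps the shared core but carries 5-(trifluoromethyl)pyridin-2-yl in place of 4-ethylphenyl on a sulfur. The entering ring holds a hetero atom, which neither measured compound has at this place, so the data do not test this kind of change directly.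

Within the data shown here, the only measured step that bears on it is a number 1.5 percentage points lower from compound 1 to compound 2 (within the scatter) for a change of the group on the same sulfur. On that slim evidence, no step beyond the scatter is expected in this assay although a larger rise cannot be ruled out. The expected step is a number 3.3 percentage points higher from compound 2 to compound 3 (within the scatter) as an estimate only. For compound 3 the estimated value is 6% with an expected range from 0% to 20% in this test.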

Compound 3, percent growth inhibition at one concentration: 14.9%
Compound 3: middle estimate off by 8.9 percentage points, on the low side; low and high end bracket the measured number.
By their numbers in this assay, from the lowest: compounds 2 and 1 (each within the scatter of the next); then compound 3.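

In this assay, placing 5-(trifluoromethyl)pyridin-2-yl on the sulfur gives a number 12.2 percentage points higher from compound 2 to compound 3 (beyond the scatter), and the same group gives a number 10.7 percentage points higher from compound 1 to compound 3 (beyond the scatter). Among these compounds, compound 1 and compound 2 both carry a six-membered aromatic ring of carbon only on the sulfur and cannot be told apart, so this is the first change here to move the read-out beyond the scatter, showing that this position can affect growth inhibition, although compound 3 reaches only 14.9% in this assay. Nothing measured here explains why this exchange raises the number.

The entering group differs from both earlier groups by a ring nitrogen and a trifluoromethyl group at once, so the compounds shown cannot say which of the two matters, or whether both are needed; a plain pyridin-2-yl group and a 4-(trifluoromethyl)phenyl group on the same sulfur would help separate them. Also open, as far as these compounds go, are whether an amine or a carboxylic acid on this ring would change the number further, and how compound 3 behaves at other concentrations.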